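Swapping the ring on the sulfonamide nitrogen

The source may hold more compounds than are shown below. What is called first, only, known or untested is meant among the compounds shown, and "the series" means these compounds.

Compound 1 `CCc1ccccc1N(CC(=O)NCc1ccc(OC)c(OC)c1)S(=O)(=O)c1ccc(C)cc1`: 25.1 nM
Compound 2 `CCc1ccccc1N(CC(=O)NCc1cccc(Cl)c1)S(=O)(=O)c1ccc(C)cc1`: 251 nM
Compound 3 `Cc1ccc(S(=O)(=O)N(CC(=O)NCc2ccc(Cl)cc2)c2ncccc2C)cc1`: 794 nM

In an assay on CHO cells for displacement of a labelled ligand from prostaglandin E2 receptor EP1 subtype (Homo sapiens) (a lower number here means a stronger inhibitor, a higher number a weaker inhibitor), compound 3 gives the highest number of the three; compound 2 with 251 nM is nearest to it, compound 1 with 25.1 nM furthest. Compound 4 `CCn1nccc1N(CC(=O)NCc1ccc(Cl)cc1)S(=O)(=O)c1ccc(C)cc1` differs from compound 3 by 1-ethyl-1H-pyrazol-5-yl in place of 3-methylpyridin-2-yl on a sulfonamide nitrogen. Among the compounds with values here, the only measured step, a 10-fold higher number from compound 1 to compound 2 (1.00 log units; beyond the scatter), concerns the group on the amide side, not the sulfonamide nitrogen, so no measured step bears on this change, and the data give no direction for it. Compound 4 is therefore expected to stay close to compound 3, a step of a 1.0-fold higher number from compound 3 to compound 4 (0.00 log units; within the scatter) in this assay, and its value is estimated at 800 nM, between 250 nM and 2500 nM.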

Compound 4, inhibition constant: 158 nM
Compound 4: middle estimate off by 5.1-fold (0.70 log units), on the high side; the measured number lies below the stated range.
By their numbers in this assay, from the lowest: compound 1; then compounds 4 and 2 (each within the scatter of the next); then compound 3.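

Within the data shown here, changing the ring on the sulfonamide nitrogen clearly moves the number in this assay, with a 5.0-fold lower number from compound 3 to compound 4 (0.70 log units; beyond the scatter) as the first measured step at this position. A five-membered aromatic ring carrying an ethyl group thus gives a stronger inhibitor here than a six-membered one carrying a methyl group. No measured evidence explains this gain.

The swap alters ring size, hetero atoms and the alkyl group all at once, so the compounds shown cannot say which of these matters. A 1-methyl-1H-pyrazol-5-yl group or a thiophene ring on this nitrogen would help to separate them.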